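Swapping ethynyl for a chloropyridinyl triazole

The compounds below may be only part of what the source reports. "The series", "measured", "known", "first", "only" and "open" are said of these compounds alone.

Measured so far in a functional assay on HCT-116 cells (Homo sapiens) for inhibition, read by sulforhodamine B assay, with a stated time of 48 h, tested at 50 uM; a lower number here means less inhibition of growth, a higher number more inhibition of growth at the concentration tested

Compound 1 `COc1ccc([C@@H]2C/C(=N/OCc3cn(-c4ccc(Cl)cc4C)nn3)c3cc(CC=C(C)C)c(OC)cc3O2)cc1` gives 20%
Compound 2 `C#CCO/N=C1/C[C@@H](c2ccc(OC)cc2)Oc2cc(OC)c(CC=C(C)C)cc21` gives 65%

Compound 2 stands higher of the two, and compound 1 lies below it by more than the usual scatter. Compound 3 `COc1ccc([C@@H]2C/C(=N/OCc3cn(-c4cccnc4Cl)nn3)c3cc(CC=C(C)C)c(OC)cc3O2)cc1` differs from compound 2 in one group: 1-(2-chloropyridin-3-yl)-1H-1,2,3-triazol-4-yl in place of ethynyl on a saturated chain carbon bound to an oxygen on an unsaturated carbon on a saturated chain carbon bound to an oxygen on an unsaturated carbon. Compound 1 also carries a triazole at that place and gives 20% in this assay so a fall beyond the scatter is expected. The estimated step is a number 35 percentage points lower from compound 2 to compound 3 (beyond the scatter) and this remains an expectation. Compound 3 is expected at 30% within an estimated range of 10% to 55%.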

Compound 3, percent growth inhibition at one concentration: 47%
Compound 3: the middle estimate sits 17 percentage points below what was measured; the range from low to high includes it.
By their numbers in this assay, from the lowest: compound 1; then compound 3; then compound 2.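

Within this assay, 1-(2-chloropyridin-3-yl)-1H-1,2,3-triazol-4-yl in place of ethynyl gives a number 18 percentage points lower from compound 2 to compound 3 (beyond the scatter) and so lowers growth inhibition without abolishing it. Changing only the group on the aromatic nitrogen of the triazole, from 4-chloro-2-methylphenyl to 2-chloropyridin-3-yl, gives a number 27 percentage points higher from compound 1 to compound 3 (beyond the scatter) and shows that the result depends on that group, not just on the triazole being present. Nothing available explains either step.

On these data alone, whether a triazole carrying an amine or a carboxylic acid on its aromatic ring would recover the growth inhibition of compound 2 remains open. So does the effect of a longer chain ending in ethynyl.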